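Working notes: dimethoxyphenyl swap on a shared core

A few compounds are considered here, and "the series" means these few. Any claim that something is new, unique, unknown or untested is made for them only; others in the source may bear on it.

Compound 1 `COc1ccc(OC)c(C(=O)/C=C/c2cn(-c3ccccc3)nc2-c2ccsc2)c1` is measured in a functional assay on HCT-116 cells (Homo sapiens) for inhibition, read by sulforhodamine B assay, with a stated time of 72 h; on this read-out higher numbers stand for weaker inhibition and lower numbers for stronger inhibition; compound 1 gives 3400 nM. Compound 2 `COc1ccc(C(=O)/C=C/c2cn(-c3ccccc3)nc2-c2ccsc2)c(OC)c1` carries 2,4-dimethoxyphenyl in place of 2,5-dimethoxyphenyl on a carbonyl carbon and gives 2200 nM, a step of a 1.5-fold lower number from compound 1 to compound 2 (0.19 log units; within the scatter). Compound 3 `COc1ccc(OC)c(C(=O)/C=C/c2cn(-c3ccccc3)nc2-c2ccncc2)c1` differs from compound 1 by pyridin-4-yl in place of thiophen-3-yl on an aromatic carbon; compound 3 gives 900 nM; the step is a 3.8-fold lower number from compound 1 to compound 3 (0.58 log units; beyond the scatter), which leaves compound 3 with the lowest number of the three. Compound 4 `COc1ccc(C(=O)/C=C/c2cn(-c3ccccc3)nc2-c2ccncc2)c(OC)c1` is not yet measured; relative to compound 3 it carries 2,4-dimethoxyphenyl in place of 2,5-dimethoxyphenyl on a carbonyl carbon, the same change as made between compound 1 and compound 2, with the place described in the same words. For the measured compounds named here, the step from compound 3 to compound 4 is expected to be a 1.5-fold lower number from compound 3 to compound 4 (0.18 log units; within the scatter), resting on the earlier step of a 1.5-fold lower number from compound 1 to compound 2 (0.19 log units; within the scatter) in this assay, the only instance seen so far. Compound 4 is therefore expected to give 600 nM, within a range from 300 nM to 1500 nM.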

Compound 4, half-maximal inhibitory concentration: 4400 nM
Beside the measured number, compound 4's estimate is 7.3-fold (0.87 log units) below it; measured number outside the range, above it.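

In this assay, 2,4-dimethoxyphenyl in place of 2,5-dimethoxyphenyl on a carbonyl carbon gives a 4.9-fold higher number from compound 3 to compound 4 (0.69 log units; beyond the scatter), so the result from the core of compound 1 does not carry over to the core of compound 3: the same change on two cores in this assay, a 1.5-fold lower number (0.19 log units; within the scatter) from compound 1 to compound 2 and a 4.9-fold higher number (0.69 log units; beyond the scatter) from compound 3 to compound 4, 7.6-fold (0.88 log units) apart, beyond the scatter of two such steps. Pyridin-4-yl in place of thiophen-3-yl on an aromatic carbon gives a 2.0-fold higher number from compound 2 to compound 4 (0.30 log units; within the scatter), and this change also depends on its context: the same change on two cores in this assay, a 3.8-fold lower number (0.58 log units; beyond the scatter) from compound 1 to compound 3 and a 2.0-fold higher number (0.30 log units; within the scatter) from compound 2 to compound 4, 7.6-fold (0.88 log units) apart, beyond the scatter of two such steps. Across these four compounds, the two changes therefore cannot be treated as independent, although a single comparison for each change does not show why they interact or how widely this holds in the series.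

As far as these compounds go, it remains open whether the same dependence appears when a methoxy group on the dimethoxyphenyl ring gives way to an amine or a carboxylic acid.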